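Aryl amide variation in a quinoline ether series: solubility

The source may hold more compounds than are shown below. What is called first, only, known or untested is meant among the compounds shown, and "the series" means these compounds.

The shared core of compound 1 `COc1ccc2nc(C)cc(OCC(=O)Nc3ccccc3)c2c1` carries an amide whose nitrogen bears a plain phenyl group; in a physicochemical assay for solubility, in phosphate buffer, measured as kinetic solubility, with a stated time of 1 h, at pH 7.4 (on this read-out lower numbers stand for lower solubility and higher numbers for higher solubility), compound 1 gives 63000 nM. Compound 2 `COc1ccc2nc(C)cc(OCC(=O)Nc3cc(C)ccc3OC)c2c1` gives 9500 nM and compound 3 `COc1ccc2nc(C)cc(OCC(=O)Nc3cc(C)c(F)c(C)c3)c2c1` gives 31500 nM. Compound 3 stands second of the three numbers; its step from compound 1 is a 2.0-fold lower number from compound 1 to compound 3 (0.30 log units; within the scatter), whereas a 3.3-fold higher number from compound 2 to compound 3 (0.52 log units; beyond the scatter) marks a modest gain.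

Compound 4 `COc1ccc2nc(C)cc(OCC(=O)Nc3ccncn3)c2c1` has not been measured. The change from compound 3 is pyrimidin-4-yl in place of 4-fluoro-3,5-dimethylphenyl on an amide-type nitrogen. Among the measured compounds shown here, no measured step swaps the aryl group on the amide nitrogen for a heteroaryl, so the bearing steps are only indirect: a 6.6-fold lower number from compound 1 to compound 2 (0.82 log units; beyond the scatter) and a 3.3-fold higher number from compound 2 to compound 3 (0.52 log units; beyond the scatter) show that rearranging substituents on that ring moves this assay by modest amounts, and a 2.0-fold lower number from compound 1 to compound 3 (0.30 log units; within the scatter) shows that adding substituents can leave it within the scatter. Since the pyrimidin-4-yl group brings two hydrogen-bond acceptors where the leaving ring has none, and compound 1 with the smallest ring gives 63000 nM, an upward step a 2.5-fold higher number from compound 3 to compound 4 (0.40 log units; beyond the scatter) is expected. The estimated value for compound 4 is 80000 nM, within 25000 nM to 250000 nM.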

Compound 4, solubility: 27500 nM
Estimate against measurement, compound 4: 2.9-fold (0.46 log units) above, within the range that was stated.
By their numbers in this assay, from the lowest: compound 2; then compounds 4, 3 and 1 (each within the scatter of the next, the first and the last beyond it).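

On the amide-type nitrogen, pyrimidin-4-yl and 4-fluoro-3,5-dimethylphenyl cannot be told apart in this assay (a 1.1-fold lower number from compound 3 to compound 4 (0.06 log units; within the scatter)), so this exchange of a carbon-only ring for a ring with 2 hetero atoms leaves the read-out within the scatter. The other two comparisons place the heteroaryl compound inside the span set by the aryl groups, with a 2.9-fold higher number from compound 2 to compound 4 (0.46 log units; beyond the scatter) on one side and a 2.3-fold lower number from compound 1 to compound 4 (0.36 log units; beyond the scatter) on the other, both modest steps beyond the scatter. The entering ring thus carries 2 hydrogen-bond acceptors where phenyl carries 0, yet compound 1 keeps the higher number, and no measurement shown here accounts for this outcome.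

The four compounds leave open whether a pyridin-4-yl group on the same amide nitrogen would read like pyrimidin-4-yl or like phenyl, and whether an amine or a carboxylic acid carried on that ring would take the number outside the span of compound 2 to compound 1. Going by these compounds, the shared core stays the same throughout, so it also remains open whether these steps hold with a group other than methoxy on it.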